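Fluoro-to-methyl swaps and solubility across the shared core

A few compounds are considered here, and "the series" means these few. Any claim that something is new, unique, unknown or untested is made for them only; others in the source may bear on it.

Measured so far in a physicochemical assay for solubility, read by HPLC, measured as thermodynamic solubility, with a stated time of 4 h, at pH 6.8; a higher number here means a more soluble compound, a lower number a less soluble compound:
- compound 1 `Cc1ccc(Oc2ccc3nc(COc4cccc(C(=O)O)c4)n(C)c3n2)cc1F`: 5.2 ug/mL
- compound 2 `Cc1ccc(Oc2ccc3nc(COc4cccc(C(=O)O)c4)n(C)c3n2)cc1C`: 16 ug/mL
- compound 3 `Cn1c(COc2cccc(C(=O)O)c2)nc2ccc(Oc3ncc(Cl)cc3F)cc21`: 10 ug/mL

Among the compounds with values here, the single measured step is methyl in place of fluoro on an aromatic carbon, which gave a 3.1-fold higher number from compound 1 to compound 2 (0.49 log units; beyond the scatter). Compound 3 carries a different aryl ether; the difference between the two cores is not broken down here, and compound 3 sits within the scatter of both compound 1 and compound 2 in this assay.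

Compound 4 `Cc1cc(Cl)cnc1Oc1ccc2nc(COc3cccc(C(=O)O)c3)n(C)c2c1` repeats the same kind of change on compound 3: methyl in place of fluoro on an aromatic carbon. The surroundings differ, since here the carbon lies on a six-membered aromatic ring with one nitrogen, ortho to a large group, two atoms from the ring nitrogen and meta to a chloro group, rather than on a ring of carbon only, ortho to a methyl group and meta to a large group. On the strength of compound 1 to compound 2 alone, the step of a 1.8-fold higher number from compound 3 to compound 4 (0.26 log units; within the scatter) is expected to be of similar size but is uncertain. Compound 4 is estimated at 18 ug/mL, within 7 ug/mL to 45 ug/mL, in this assay.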

Compound 4, solubility: 3.9 ug/mL
Beside the measured number, compound 4's estimate is 4.6-fold (0.66 log units) above it; the measured number lies below the stated range.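

In this assay methyl in place of fluoro on an aromatic carbon gave a 3.1-fold higher number from compound 1 to compound 2 (0.49 log units; beyond the scatter) but a 2.6-fold lower number from compound 3 to compound 4 (0.41 log units; beyond the scatter), so the same change ran in opposite directions on the two cores, each step beyond the scatter. With only these two pairs, the direction of this change did not carry from one core to the other, but the data do not show which difference between the cores goes with the reversal. Nothing available bears on why the two steps differ.

Still open, going by these compounds, is how an amine or a nitrile in place of the fluoro of compound 3 would compare. Also open, on these data alone, is which direction the same swap would take on any further core.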